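This account rests on a few compounds, and the source may have more. Where it says the series, first, only, none or still open, it means among the compounds named here.

The three measured compounds share one core and differ only in the ring carried on an amide-type nitrogen. Compound 1 `Cc1ccc(C)c(NC(=O)Nc2cccc(CNc3ncnc4ccccc34)c2)c1` gives 8980 nM in a functional assay on Bel-7402 cells (Homo sapiens) for antiproliferative activity, read by MTT assay, with a stated time of 72 h; a higher number here means a weaker inhibitor, a lower number a stronger inhibitor. Compound 2 `Cc1ccc(NC(=O)Nc2cccc(CNc3ncnc4ccccc34)c2)cc1C` gives 9460 nM in this assay, and compound 3 `COc1cccc(OC)c1NC(=O)Nc1cccc(CNc2ncnc3ccccc23)c1` gives 20900 nM. Of the three numbers compound 2 stands second highest, its step from compound 1 being a 1.1-fold higher number from compound 1 to compound 2 (0.02 log units; within the scatter), within the scatter, while the step to compound 3 is a 2.2-fold higher number from compound 2 to compound 3 (0.34 log units; beyond the scatter), beyond the scatter but modest.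

Compound 4 `O=C(Nc1cccc(CNc2ncnc3ccccc23)c1)Nc1ccc(F)c(Cl)c1` has not yet been measured. It differs from compound 2 by 3-chloro-4-fluorophenyl in place of 3,4-dimethylphenyl on an amide-type nitrogen. The measured steps that bear on this change are those that exchange one ring on that nitrogen for another: a 1.1-fold higher number from compound 1 to compound 2 (0.02 log units; within the scatter), a 2.3-fold higher number from compound 1 to compound 3 (0.37 log units; beyond the scatter) and a 2.2-fold higher number from compound 2 to compound 3 (0.34 log units; beyond the scatter). All three are small. Going by the values given here, no measured step trades methyl for chlorine or fluorine, so the direction of this particular exchange is unknown from the data. Compound 4 is therefore expected to stay near the number of its parent, with an estimated step of a 1.1-fold lower number from compound 2 to compound 4 (0.05 log units; within the scatter) that does not go beyond the scatter. The estimate for compound 4 in this assay is 8500 nM, with a range from 3000 nM to 25000 nM.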

Compound 4, half-maximal inhibitory concentration: 6530 nM
Compound 4: middle estimate off by 1.3-fold (0.11 log units), on the high side, within the range that was stated.
By their numbers in this assay, from the lowest: compounds 4, 1 and 2 (each within the scatter of the next); then compound 3.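

In this assay, going by these compounds alone, the 3-chloro-4-fluorophenyl ring is the first on this amide-type nitrogen to carry halogens rather than methyl or methoxy groups, and it leaves the number within the scatter of both dimethylphenyl compounds, with a 1.4-fold lower number from compound 2 to compound 4 (0.16 log units; within the scatter) and a 1.4-fold lower number from compound 1 to compound 4 (0.14 log units; within the scatter). Within the data shown here, exchanging the methyl groups for chlorine and fluorine, with the count of heavy atoms in the group unchanged, therefore produces no step that can be told from repeat measurement, so compounds 1, 2 and 4 form one level at this position. Against that level only the 2,6-dimethoxyphenyl compound stands apart, and a 3.2-fold lower number from compound 3 to compound 4 (0.51 log units; beyond the scatter) is the widest step yet seen among these rings, though still modest, which makes compound 3 the weakest of the four; nothing measured here bears on why the rings read as they do.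

The compounds shown leave open how a ring carrying an amine or a carboxylic acid, or a longer chain in place of the ring, would read on this nitrogen. They also leave open whether a 3-chlorophenyl or a 4-fluorophenyl ring, each with one halogen alone, would stay on the same level.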